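Series notes: aryl swap on the alkene carbon of compound 1

The compounds below may be only part of what the source reports. "The series", "measured", "known", "first", "only" and "open" are said of these compounds alone.

Compound 1 `Cc1ccc(S/C(=C/c2ccc(Br)cc2)C(=O)c2ccc(Cl)cc2)cc1` gives the highest of the two numbers measured in a functional assay on DU-145 cells (Homo sapiens) for inhibition, read by trypan blue exclusion, with a stated time of 96 h (a lower number here means a stronger inhibitor of growth, a higher number a weaker inhibitor of growth), at 25000 nM. Within the data shown here, its only measured neighbour is compound 2 `O=C(/C(=C\c1ccc(Br)cc1)SCc1ccc(Cl)cc1)c1ccc(Cl)cc1`, which in this assay gives 1000 nM; the single step of a 25-fold lower number from compound 1 to compound 2 (1.40 log units; beyond the scatter) comes from 4-chlorobenzyl in place of 4-methylphenyl on a sulfur, a different place from the change considered here.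

Compound 3 `Cc1ccc(S/C(=C/c2sccc2C)C(=O)c2ccc(Cl)cc2)cc1` differs from compound 1 by 3-methylthiophen-2-yl in place of 4-bromophenyl on a double-bonded chain carbon bound to a double-bonded chain carbon. Among the measured compounds shown here, no measured pair varies the group on the double-bonded chain carbon, so the one known step cannot be carried over, and nothing in the data points to a direction. Absent such evidence, the step of no change at the digits printed from compound 1 to compound 3 (within the scatter) is expected to stay within the scatter. Compound 3 is therefore estimated at 25000 nM in this assay, with a range from 8000 nM to 80000 nM.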

Compound 3, concentration for 50% growth inhibition: 50000 nM
For compound 3 the middle estimate is 2.0-fold (0.30 log units) below the measured one; the measured number falls inside the stated range.
By their numbers in this assay, from the lowest: compound 2; then compounds 1 and 3 (each within the scatter of the next).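

Among these compounds, this is the first reading at the aryl position on the double-bonded chain carbon: in this assay, 3-methylthiophen-2-yl in place of 4-bromophenyl gives a 2.0-fold higher number from compound 1 to compound 3 (0.30 log units; within the scatter) and so does not separate the two groups. Among the compounds shown here, with 4-methylphenyl on the sulfur, this swap thus differs from the one earlier change, 4-chlorobenzyl in place of 4-methylphenyl on a sulfur, which gave a 25-fold lower number from compound 1 to compound 2 (1.40 log units; beyond the scatter) and lay beyond the scatter. No accompanying measurement offers an explanation for this result.

Going by these compounds, whether the same swap would also stay within the scatter with the 4-chlorobenzyl group of compound 2 on the sulfur remains open. Also open, on these data alone, is how a group of another kind at this position, such as an amine, a carboxylic acid or a longer alkyl chain, would read.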